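The source may hold more compounds than are shown below. What is called first, only, known or untested is meant among the compounds shown, and "the series" means these compounds.

In an assay on V79MZh cells for inhibition of cytochrome P450 11B2, mitochondrial (Homo sapiens), with a stated time of 30 min (on this read-out lower numbers stand for stronger inhibition and higher numbers for weaker inhibition), compound 1 `O=c1cc(Cc2ccncc2)oc2ccccc12` gives 1240 nM. For compound 2 `COc1ccc2c(=O)cc(Cc3ccncc3)oc2c1` this assay reports only a limit, > 5000 nM. So compound 2 sits at the limit of > 5000 nM in this assay, at which 1 of the 2 values shown sits. Among the measured compounds shown here, the only measured change is an at least 4.0-fold higher number from compound 1 to compound 2 (0.60 log units; beyond the scatter), a step beyond the scatter. Compound 3 `O=c1cc(Cc2ccncc2)oc2cc(F)ccc12` differs from compound 2 by fluoro in place of methoxy on an aromatic carbon. For the measured compounds named here, no measured step covers a fluoro group, but since adding methoxy gave an at least 4.0-fold higher number from compound 1 to compound 2 (0.60 log units; beyond the scatter), taking it away is expected to pull the number back toward that of compound 1. Compound 3 is therefore estimated at 1500 nM, between 500 nM and 5000 nM, an expected change of an at least 3.3-fold lower number from compound 2 to compound 3 (0.52 log units; beyond the scatter).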

Compound 3, half-maximal inhibitory concentration: 643 nM
The estimate for compound 3 lay 2.3-fold (0.37 log units) above the measured number, and the stated range covers the measured number.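

At this position on the shared core, not every replacement for hydrogen ends in the same place as methoxy: fluoro gives an at least 7.7-fold lower number from compound 2 to compound 3 (0.89 log units; beyond the scatter). For compound 2, the starting value of > 5000 nM is a limit of the assay, not a number. Fluoro in place of hydrogen gives a 1.9-fold lower number from compound 1 to compound 3 (0.29 log units; within the scatter), so compound 1 and compound 3 cannot be told apart here.

Going by these compounds, whether an amine or a longer chain at this position would behave like fluoro or like methoxy remains open. So does what fluoro would do on another carbon of this ring.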